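A few compounds are considered here, and "the series" means these few. Any claim that something is new, unique, unknown or untested is made for them only; others in the source may bear on it.

Measured in a functional assay on HT-29 cells (Homo sapiens) for inhibition, with a stated time of 72 h; a higher number here means a weaker inhibitor, a lower number a stronger inhibitor:
- Compound 1 `COc1cc(C(=O)c2ccc3c(ccn3C(C)C)c2)cc(OC)c1OC`: 1200 nM
- Compound 2 `COc1cc(C(=O)c2ccc3c(ccn3CC(=O)O)c2)cc(OC)c1OC`: 460 nM
- Compound 3 `COc1cc(C(=O)c2ccc3c(ccn3CCC(=O)O)c2)cc(OC)c1OC`: > 10000 nM

Compound 3 stands at > 10000 nM, which is a limit of the assay and not a number. Compound 4 `COc1cc(C(=O)c2ccc3c(ccn3CCN(C)C)c2)cc(OC)c1OC` differs from it as follows: dimethylamino in place of carboxy on a saturated chain carbon, two bonds along the chain from an aromatic nitrogen. In words, this is dimethylamino in place of carboxy on a saturated chain carbon, two bonds along the chain from an aromatic nitrogen.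

Among the measured compounds shown here, no measured step makes this exchange. The nearest steps change the group on the same nitrogen: a 2.6-fold lower number from compound 1 to compound 2 (0.42 log units; beyond the scatter), an at least 8.3-fold higher number from compound 1 to compound 3 (0.92 log units; beyond the scatter) and, the largest, an at least 21-fold higher number from compound 2 to compound 3 (1.33 log units; beyond the scatter). These steps run in both directions, so they give only a loose guide. The carboxy group of compound 3 leaves, and the expectation is a clearly lower number, close to compound 1 at 1200 nM.

Compound 4 is estimated at 1500 nM. Its expected range runs from 300 nM to 8000 nM. The expected step is an at least 6.6-fold lower number from compound 3 to compound 4 (0.82 log units; beyond the scatter).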

Compound 4, half-maximal inhibitory concentration: 4600 nM
Estimate against measurement, compound 4: 3.1-fold (0.49 log units) below; the measured number falls inside the stated range.
By their numbers in this assay, from the lowest: compound 2; then compound 1; then compound 4. At a limit, above all of these: compound 3.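

In this assay, dimethylamino in place of carboxy on a saturated chain carbon, two bonds along the chain from an aromatic nitrogen, gives an at least 2.1-fold lower number from compound 3 to compound 4 (0.33 log units; beyond the scatter), so a chain of this length can give a measured value when it ends in dimethylamino. That step is a bound and not an exact size, as compound 3 is held at a limit of the assay: the limit of > 10000 nM in this assay, at which 1 of the 4 values shown sits.
Even so, the 2-(dimethylamino)ethyl group does not reach the isopropyl or carboxymethyl groups on that nitrogen, with a 3.8-fold higher number from compound 1 to compound 4 (0.58 log units; beyond the scatter) and a 10-fold higher number from compound 2 to compound 4 (1.00 log units; beyond the scatter).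

The compounds shown leave open how far compound 3 really lies from compound 4. They also leave open how a primary amine or a morpholine at the end of the same chain, or a longer chain ending in dimethylamino, would read.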